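Swapping the outer aryl ring in a nitrile-bearing amide series

The source may report more compounds than this note shows. Statements on the series, on what has been measured and on what is new or still open speak of the compounds shown alone.

For the measured compounds named here, compound 1 `CC[C@@H](Nc1c(C#N)c(-c2ccc(-c3cccc(C)c3F)cc2)nc2cnccc12)C(N)=O` has the higher of the two numbers measured so far: in a physicochemical assay for lipophilicity, read by HPLC, at pH 7.5 (on this read-out higher numbers stand for higher lipophilicity and lower numbers for lower lipophilicity), compound 1 gives 3, while compound 2 `CCOc1ccccc1-c1ccc(-c2nc3cnccc3c(N[C@H](CC)C(=O)NS(C)(=O)=O)c2C#N)cc1` gives 2.2, a gap that lies beyond the scatter. Compound 3 `CC[C@@H](Nc1c(C#N)c(-c2ccc(-c3cccc(Cl)c3)cc2)nc2cnccc12)C(N)=O` is not yet measured. It differs from compound 1 by 3-chlorophenyl in place of 2-fluoro-3-methylphenyl on an aromatic carbon. Nothing measured here separates these two groups, so no step beyond the scatter is expected in this assay in either direction. Compound 3 is therefore estimated at 3, between 2.6 and 3.4, an expected step of no change at the digits printed from compound 1 to compound 3 (within the scatter).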

Compound 3, distribution coefficient: 3.1
Estimate against measurement, compound 3: 0.10 log units below, and the stated range covers the measured number.
By their numbers in this assay, from the lowest: compound 2; then compounds 1 and 3 (each within the scatter of the next).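

In this assay the change to 3-chlorophenyl in place of 2-fluoro-3-methylphenyl gives a number 0.10 log units higher from compound 1 to compound 3 (within the scatter) and so shows that, at this place para to a large group, these two aromatic rings of carbon only are not told apart by this read-out. Nothing measured here bears on the reason for this result. As far as these compounds go, whether an amine or a carboxylic acid on the outer ring would move the number beyond the scatter stays open. Compound 2 differs from compound 1 in more than one place, so its number cannot be assigned to either change.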